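A few compounds are considered here, and "the series" means these few. Any claim that something is new, unique, unknown or untested is made for them only; others in the source may bear on it.

The account follows a set of amides built on a shared core. Compound 1 `O=C(CN1CCN(c2ccncc2)CC1)Nc1nc2c(s1)CCCC2` carries a pyridin-4-yl group on the ring nitrogen, and in an assay on isolated protein for inhibition of long-chain fatty acid transport protein 1 (Mus musculus), read by scintillation counting, with a stated time of 20 min (a lower number here means a stronger inhibitor, a higher number a weaker inhibitor), compound 1 gives only a limit, > 10000 nM. Compound 2 `O=C(CN1CCN(c2cccc(F)c2)CC1)Nc1nc2c(s1)CCCC2` carries a 3-fluorophenyl group in its place, and in this assay compound 2 likewise gives only a limit, > 10000 nM. The step that the two limits leave unreadable from compound 1 to compound 2 therefore cannot be read, both values sitting at the limit of > 10000 nM in this assay, at which 2 of the 3 values shown sit. Among the compounds with values here, compound 3 `Cc1nc(NC(=O)CN2CCN(c3ccc(F)cc3)CC2)sc1C` has a different core and a 4-fluorophenyl group; in this assay compound 3 gives 1700 nM, the single number among the three. Compound 2 thus stands at a limit, with nothing measured to place it more closely.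

Compound 4 `O=C(CN1CCN(c2ccc(F)cn2)CC1)Nc1nc2c(s1)CCCC2` differs from compound 2 in one place: 5-fluoropyridin-2-yl in place of 3-fluorophenyl on an amine nitrogen in a ring. Within the data shown here, no measured step bears directly on this change; the one step within this core is unreadable, and compound 3 sits on another core. The expectation for compound 4 is therefore that it stays close to compound 2 and most likely again returns only a limit. The step that the limit leaves unreadable from compound 2 to compound 4 is expected to be small. Compound 4 is estimated at 15000 nM, within 4000 nM to 50000 nM.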

Compound 4, half-maximal inhibitory concentration: 600 nM
Compound 4: middle estimate off by 25-fold (1.40 log units), on the high side, and the stated range ends above it.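

On the shared core, the group on the amine nitrogen of the six-membered non-aromatic ring with 2 nitrogen proves able to move the result in this assay: 5-fluoropyridin-2-yl in place of 3-fluorophenyl gives an at least 16-fold lower number from compound 2 to compound 4 (1.22 log units; beyond the scatter), and the same group in place of pyridin-4-yl gives an at least 16-fold lower number from compound 1 to compound 4 (1.22 log units; beyond the scatter). Having a ring nitrogen in the aromatic ring does not by itself bring a measurable number, since compound 1, with its pyridin-4-yl group, gives only a limit, > 10000 nM. Both steps are open-ended, and their full size cannot be read, because each starts from a compound that sits at a limit: the limit of > 10000 nM in this assay, at which 2 of the 4 values shown sit.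

The two steps swap more than one feature of the aromatic ring at once, so they do not separate the part played by the ring nitrogen from that played by the fluorine, and a plain pyridin-2-yl group or a 5-chloropyridin-2-yl group would be needed to tell them apart. From the compounds shown here alone, it also remains open whether 5-fluoropyridin-2-yl would bring a similar gain on the core of compound 3, or whether a methyl or nitrile group could stand in place of its fluorine.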